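Methoxy on a Phenyl Ring: Three Limits and a Fourth Compound

This account rests on a few compounds, and the source may have more. Where it says the series, first, only, none or still open, it means among the compounds named here.

Compound 1 `COc1cccc(-c2ncnn2-c2cc(OC)c(OC)c(OC)c2)c1`, compound 2 `COc1cc(-c2ncnn2-c2ccccc2)cc(OC)c1OC` and compound 3 `COc1cc(-n2ncnc2-c2ccccc2)cc(OC)c1OC` were tested in a functional assay on MCF7 cells (Homo sapiens) for antiproliferative activity, read by MTT assay, with a stated time of 72 h; on this read-out lower numbers stand for stronger inhibition and higher numbers for weaker inhibition. In this assay compound 1 gives > 10000 nM, which is a limit of the assay and not a number. Compound 2 likewise gives > 10000 nM, again a limit. Compound 3 gives > 10000 nM, also a limit. The difference between the cores of compound 2 and compound 3 is not broken down here. From compound 3 to compound 1 the change is methoxy in place of hydrogen on an aromatic carbon, and a step that the two limits leave unreadable from compound 3 to compound 1. Compound 4 `COc1ccc(-n2ncnc2-c2cc(OC)c(OC)c(OC)c2)cc1` carries the same kind of change from compound 2, (methoxy in place of hydrogen on an aromatic carbon), though here the methoxy sits para to a large group rather than meta to a large group. Because the three measured values all sit at the limit of > 10000 nM in this assay, at which 3 of the 3 values shown sit, only a small step is expected, a step that the limit leaves unreadable from compound 2 to compound 4. Compound 4 is therefore estimated at 20000 nM.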

Compound 4, half-maximal inhibitory concentration: 7400 nM
For compound 4 the middle estimate is 2.7-fold (0.43 log units) above the measured one; the whole stated range lies above it.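

Compound 2 gives > 10000 nM, which is a limit of the assay and not a number. In this assay, the change of phenyl to 4-methoxyphenyl gives an at least 1.3-fold lower number from compound 2 to compound 4 (0.13 log units; that floor lies within the scatter), so the true step may be larger, but the part that can be stated stays within the usual scatter. The same kind of change on the other core cannot be read, and there the methoxy stands at a different place, so carrying the change from one core to the other is not shown: the limit of > 10000 nM in this assay, at which 3 of the 4 values shown sit.

Compound 4 alone gives a number rather than a limit. Left open is how an amine, a hydroxyl or a longer chain such as ethoxy would read in place of the methoxy on compound 4.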